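This account rests on a few compounds, and the source may have more. Where it says the series, first, only, none or still open, it means among the compounds named here.

Of the compounds shown here, three sharing one core have been measured in an assay on HEK293 cells for agonist activity at transient receptor potential cation channel subfamily M member 8 (Homo sapiens), read by fluorescence and calcium flux, with a stated time of 15 min; a lower number here means that less compound is needed, a higher number that more compound is needed for the effect. Compound 1 `CCN(Cc1ccc(C)s1)C(=O)COc1ccc(C)cc1` gives 178 nM in this assay. Compound 3 `CCN(Cc1cccs1)C(=O)COc1ccc(F)cc1` gives 422 nM. Compound 2 `Cc1ccc(OCC(=O)N(Cc2cccs2)CC(C)C)cc1` gives 900 nM, the highest of the three numbers; its nearest neighbour is compound 3 and its furthest is compound 1, and both gaps lie beyond the scatter. Compound 4 `Cc1ccc(OCC(=O)N(O)Cc2cccs2)cc1` has not yet been measured. It differs from compound 2 in a single place: hydroxy in place of isobutyl on an amide-type nitrogen. Among the measured compounds shown here, no step between measured compounds matches this change, so the direction rests on judgement alone. The expected step in this assay is a 3.3-fold higher number from compound 2 to compound 4 (0.52 log units; beyond the scatter), towards a higher number, beyond the scatter. The estimate for compound 4 is 3000 nM, with a range from 800 nM to 12000 nM.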

Compound 4, half-maximal effective concentration: 8000 nM
Estimate against measurement, compound 4: 2.7-fold (0.43 log units) below; measured number inside the range.
By their numbers in this assay, from the lowest: compound 1; then compound 3; then compound 2; then compound 4.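

Among the compounds shown here, on the amide-type nitrogen, the earlier compounds offered no step, and this is the first reading of a change there: in this assay, hydroxy in place of isobutyl gives an 8.9-fold higher number from compound 2 to compound 4 (0.95 log units; beyond the scatter). The number at this position therefore responds to what the nitrogen carries, and here swapping a four-carbon chain for hydroxy goes towards needing more compound. Nothing measured here bears on why the number rises. Still open, from the compounds shown here alone, is how a methoxy or an amine on this nitrogen would read. Also open, going by these compounds, is how an ethyl would compare with isobutyl with the rest of compound 2 unchanged.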